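Methoxyphenyl position shift on the cyanopyrimidinone thioether series

A few compounds are considered here, and "the series" means these few. Any claim that something is new, unique, unknown or untested is made for them only; others in the source may bear on it.

Measured in a functional assay on U-87MG ATCC cells for antiproliferative activity against U-87 MG (Homo sapiens), read by MTT assay, with a stated time of 48 h, tested at 100 uM; a lower number here means a stronger effect, a higher number a weaker effect of the compound at the concentration tested:
compound 1 `COc1ccc(-c2nc(C)c(C(=O)CSc3nc(N)c(C#N)c(-c4ccc(Cl)cc4)n3)s2)cc1`, 3.9%
compound 2 `COc1ccc(-c2nc(SCC(=O)c3sc(-c4ccccc4)nc3C)[nH]c(=O)c2C#N)cc1`, 1.08%
compound 3 `COc1ccc(-c2nc(C)c(C(=O)CSc3nc(-c4ccc(OC)cc4)c(C#N)c(=O)[nH]3)s2)cc1`, 11.5%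

Compound 2 gives the smallest of the three numbers, but compound 1 lies within the scatter of it; only compound 3 stands clearly apart, with a number 10.4 percentage points higher from compound 2 to compound 3 (beyond the scatter). That step concerns methoxy in place of hydrogen and not a shift of the methoxy around the ring.

Compound 4 `COc1cccc(-c2nc(SCC(=O)c3sc(-c4ccccc4)nc3C)[nH]c(=O)c2C#N)c1` is not yet measured. Its change from compound 2 is 3-methoxyphenyl in place of 4-methoxyphenyl on an aromatic carbon. Among the compounds with values here, no measured step shows the effect of moving the methoxy from the 4- to the 3-position, so no step beyond the scatter is expected in this assay, giving a number 2.9 percentage points higher from compound 2 to compound 4 (within the scatter). Compound 4 is therefore estimated at 4%, within 0.5% to 16%.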

Compound 4, a percentage reported as activity, at one concentration (the size of the read-out at that concentration, not a potency): 21.8%
Compound 4: the middle estimate sits 17.8 percentage points below what was measured; measured number above the stated range.
By their numbers in this assay, from the lowest: compounds 2, 1 and 3 (each within the scatter of the next, the first and the last beyond it); then compound 4.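

In this assay the swap of 4-methoxyphenyl for 3-methoxyphenyl gives a number 20.7 percentage points higher from compound 2 to compound 4 (beyond the scatter) with the same atoms joined differently, so the methoxy location on this aryl group counts here. The earlier step concerned a methoxy on another aromatic carbon and gave no reading of a shift at this position. Nothing available explains the size of this step.

Open, on these data alone, is whether an amine or a hydroxyl in place of the methoxy, or an ethoxy group, would keep the number near that of compound 2. Also open, as far as these compounds go, is whether the same shift in compound 3 acts alike.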